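A few compounds are considered here, and "the series" means these few. Any claim that something is new, unique, unknown or untested is made for them only; others in the source may bear on it.

Compound 1 (`CC(C)(C)c1cc(NC(=O)Nc2cccc(Oc3ccnc4[nH]c(=O)cnc34)c2)n(-c2ccccc2)n1`) is measured in an in vivo ADME assay on the whole organism (strain C57BL/cAnNCrl) for pharmacokinetics, with Mus musculus as the target, at a dose of 10 mg/kg by the oral route (on this read-out higher numbers stand for higher exposure at the dose given and lower numbers for lower exposure), where compound 1 gives 29500 nM. This is the higher of the two numbers at hand. Going by the values given here, the only other measured compound, compound 2 (`Cc1ccc(-n2nc(C(C)(C)C)cc2NC(=O)Nc2ccc(Oc3ccnc4[nH]c(S)nc34)cc2F)cc1`), differs from compound 1 in several places at once; in this assay compound 2 gives 11700 nM, a lower number than that of compound 1, and the gap between the two lies beyond the usual scatter. Compound 2 differs from compound 1 in more than one place, so these two values do not isolate any single change.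

Compound 3 (`Cc1ccc(-n2nc(C(C)(C)C)cc2NC(=O)Nc2cccc(Oc3ccnc4[nH]c(=O)cnc34)c2)cc1`) is not yet measured. It differs from compound 1 in one place: methyl in place of hydrogen on an aromatic carbon. Among the compounds with values here, no measured pair shows this change alone, so nothing in the numbers at hand points to a direction for it. The step of a 1.3-fold lower number from compound 1 to compound 3 (0.13 log units; within the scatter) is expected to be small, with no movement beyond the usual scatter in either direction. Compound 3 is accordingly estimated at 22000 nM in this assay, within a range from 8000 nM to 50000 nM.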

Compound 3, maximal plasma concentration: 27000 nM
Compound 3: the middle estimate sits 1.2-fold (0.09 log units) below what was measured, and the stated range covers the measured number.
By their numbers in this assay, from the lowest: compound 2; then compounds 3 and 1 (each within the scatter of the next).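

Going by these compounds alone, replacing phenyl by 4-methylphenyl gives the first pair that isolates a single change, and in this assay it reads a 1.1-fold lower number from compound 1 to compound 3 (0.04 log units; within the scatter), so the two compounds cannot be told apart on this read-out. At this place, on an aromatic carbon para to a large group, a methyl in place of hydrogen therefore leaves the maximal plasma concentration within the usual scatter, and the exposure seen with the unsubstituted phenyl is retained at the dose given. Nothing at hand speaks to why the two numbers stand so close together.

This single pair says nothing about whether the same place would accept a group other than methyl, such as chlorine, methoxy, an amine, a carboxylic acid or a longer chain such as propyl, without a step beyond the scatter. It also leaves open whether methyl would give the same result elsewhere on this ring or on a different core, as one step in one assay cannot establish a general rule.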